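Swapping a Methoxy for an Ester on the Amide Ring

The compounds below may be only part of what the source reports. "The series", "measured", "known", "first", "only" and "open" are said of these compounds alone.

Measured compounds:
compound 1, `COc1ccc(C(=O)Nc2cccc3c2N(S(=O)(=O)c2ccc(OC)cc2)CC3)cc1`, gives 1600 nM in a functional assay on MKN-45 cells (Homo sapiens) for cytotoxicity; a lower number here means a stronger inhibitor, a higher number a weaker inhibitor.
compound 2, `COc1ccc(S(=O)(=O)N2CCc3cccc(NCc4ccccc4)c32)cc1`, gives > 10000 nM in this assay.

Within the data shown here, compound 1 stands alone as the only compound with a real number here; the other value is not a number. Among the measured compounds shown here, for compound 2 the result is a limit of the assay, (the limit of > 10000 nM in this assay, at which 1 of the 2 values shown sits), so it is known only that compound 2 is a weaker inhibitor than that limit. For the measured compounds named here, the one measured step is an at least 6.2-fold higher number from compound 1 to compound 2 (0.79 log units; beyond the scatter), a large loss.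

Compound 3, `COC(=O)c1ccc(C(=O)Nc2cccc3c2N(S(=O)(=O)c2ccc(OC)cc2)CC3)cc1`, differs from compound 1 by methoxycarbonyl in place of methoxy on an aromatic carbon, that is, 4-methoxyphenyl to 4-(methoxycarbonyl)phenyl. The measured step from compound 1 to compound 2 replaces the whole amide-bearing group with a benzyl and leaves the methoxy-bearing ring untouched, so it says nothing about the change made here. Going by the values given here, no measured step bears on this change.

With nothing pulling in either direction, compound 3 is expected to stay close to compound 1, a step of no change at the digits printed from compound 1 to compound 3 (within the scatter), within the scatter. Compound 3 is estimated at 1600 nM, with a range of 500 nM to 5000 nM.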

Compound 3, half-maximal inhibitory concentration: 312 nM
For compound 3 the middle estimate is 5.1-fold (0.71 log units) above the measured one, outside the stated range (below it).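

Changing only 4-methoxyphenyl to 4-(methoxycarbonyl)phenyl gives a 5.1-fold lower number from compound 1 to compound 3 (0.71 log units; beyond the scatter) in this assay, so this position, on an aromatic carbon para to a large group, responds to a change even with the amide and the rest of the shared core left in place. The earlier step could not show this, since it replaced the whole amide-bearing group with a benzyl and so tested the amide-bearing group as a unit, not any single place on it. Here the methoxycarbonyl, which brings a carbonyl that the methoxy lacks, goes with a stronger inhibitor than the methoxy, but nothing shown explains why the number falls.

The compounds shown leave open whether this gain belongs to the methoxycarbonyl group in particular or would also appear with other groups at this position, such as a carboxylic acid, a nitrile or a primary amide. They also leave open whether a longer ester, such as ethoxycarbonyl, would hold the gain, and whether it would carry over to compounds with a different group on the sulfonyl side of the core.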